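The compounds below may be only part of what the source reports. "The series", "measured", "known", "first", "only" and "open" are said of these compounds alone.

In an assay on CHO cells for displacement of a labelled ligand from adenosine receptor A1 (Homo sapiens), read by scintillation counting, with a stated time of 1 h, tested at 1 uM (on this read-out higher numbers stand for more inhibition at the one concentration tested (going by the name of the read-out) and lower numbers for less inhibition), compound 1 `Nc1ncc(-c2ccc(O)c(Cl)c2)c(-c2ccccc2)n1` reaches the assay's limit of > 80%, a limit rather than a number, and the limit of > 80% in this assay, at which 1 of the 2 values shown sits, records it as such. Compound 2 `CCCCC(=O)Nc1ncc(-c2cccc(Cl)c2)c(-c2ccccc2)n1` gives 52%, the only plain number shown in this assay, so compound 2 stands at that single measured value with nothing else to compare it to. Compound 3 `OCCCNc1ncc(-c2cccc(Cl)c2)c(-c2ccccc2)n1` differs from compound 2 by 3-hydroxypropyl in place of butylcarbonyl on a nitrogen on an aromatic ring. Among the compounds with values here, no measured step between compounds connects to this change, so the expected step from compound 2 to compound 3 is a number 3 percentage points higher from compound 2 to compound 3 (within the scatter), a shift no larger than the usual scatter. Compound 3 is thus estimated at 55%, within 25% to 85%.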

Compound 3, a percentage reported as inhibition, at one concentration (the size of the read-out at that concentration, not a potency): > 80%
Compound 3: only a limit was reported (the forecaster's own chance of this, stated with the estimate: 15%); at least 25 percentage points between middle value and limit.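

The change on this nitrogen alone, with the rest of the structure held fixed, moves the read-out in this assay: 3-hydroxypropyl in place of butylcarbonyl gives a number at least 28 percentage points higher from compound 2 to compound 3 (beyond the scatter). This is the first comparison shown of two groups at this position, and it shows that the choice of group there matters beyond the scatter. Compound 3 stands at a limit rather than a number, so the full size of the step stays unknown: the limit of > 80% in this assay, at which 2 of the 3 values shown sit.

The compounds shown leave open whether the loss of the carbonyl or the gain of the hydroxyl carries the step, as the two groups differ in both. A plain propyl group, or a longer chain ending in hydroxyl, on this nitrogen could separate the two.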